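One ring group exchanged on compound 3

This account rests on a few compounds, and the source may have more. Where it says the series, first, only, none or still open, it means among the compounds named here.

In a toxicity assay on THP-1 cells (Homo sapiens) for cytotoxicity (a lower number here means that less compound is needed, a higher number that more compound is needed for the effect), compound 3 `O=C(NCc1ccc(F)cc1)c1ncc2c(N3CCCCS3(=O)=O)cccc2c1O` gives 31600 nM while compound 2 `CNC(=O)c1nc(-c2ccccc2OC)c2cccnc2c1O` gives 39800 nM and these two numbers sit within the usual scatter of each other. Compound 1 `Oc1c(-c2nc(C(O)c3ccccc3)n[nH]2)ncc2cccnc12` shows > 50100 nM as a limit of the assay and not as a number.

Compound 4 `O=C(NCc1ccc(F)cc1)c1ncc2c(NC3CCOCC3)cccc2c1O` is not yet measured. It carries (oxan-4-yl)amino in place of the group that compound 3 holds on an aromatic carbon of the shared core (a group of 7 heavy atoms (5 carbon, 1 nitrogen, 1 oxygen; one six-membered non-aromatic ring with 1 hetero atom) in place of a group of 8 heavy atoms (4 carbon, 1 nitrogen, 2 oxygen, 1 sulfur; one six-membered non-aromatic ring with 2 hetero atoms), on an aromatic carbon). Going by the values given here, no two measured compounds here differ in one place only, so there is no measured step to compare. The estimated step of a 1.1-fold lower number from compound 3 to compound 4 (0.05 log units; within the scatter) is expected to stay within the scatter. For compound 4 the expected value is 28000 nM with an estimated range of 10000 nM to 50000 nM in this measurement.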

Compound 4, half-maximal effective concentration in the THP-1 assay: > 50100 nM
Compound 4 ended at the assay's limit (the forecaster's own chance of this, stated with the estimate: 25%); middle value at least 1.7-fold (0.25 log units) from the limit.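

Going by these compounds alone, in the THP-1 assay the exchange on this aromatic carbon gives an at least 1.5-fold higher number from compound 3 to compound 4 (0.20 log units; that floor lies within the scatter), the first step here that can be read in one place, though that floor stays within the scatter. In the THP-1 assay compound 4 gives > 50100 nM, which is a limit of the assay and not a number. In a physicochemical assay for lipophilicity, at pH 7.4 (on this read-out higher numbers stand for higher lipophilicity and lower numbers for lower lipophilicity), compound 4 gives 5.3 while compound 3 gives "not determined" (no result reported), so no step can be read there. As far as these compounds go, the true size of the step stays unknown because compound 4 sits at a limit of the assay and not at a number: the limit of > 50100 nM in the THP-1 assay, at which 2 of the 4 values shown sit.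

From the compounds shown here alone, whether an open-chain amine such as dimethylamino or a carboxylic acid on this carbon would give a number under that limit stays open.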